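Lengthening the Chain of Compound 1

The source may hold more compounds than are shown below. What is called first, only, known or untested is meant among the compounds shown, and "the series" means these compounds.

Among the measured compounds shown here, in an ADME assay on L929 cells (Mus musculus, culture collection number NCTC 929) for cytotoxicity, read by MTT assay, with a stated time of 72 h (a lower number here means a stronger inhibitor, a higher number a weaker inhibitor), compound 1 (`CCCCCCCCCC(=O)c1c(O)cc(C)oc1=O`) gives 134000 nM, the only exact number available so far. Compound 2 (`CCCCCCc1c(O)cc(C)oc1=O`) gives no exact number, only a limit of the assay: > 200000 nM. Compound 3 (`CCCCCC(=O)c1c(O)cc(C)oc1=O`) also gives only a limit: > 200000 nM.

Compound 4 (`CCCCCCCCCCCCCCCC(=O)c1c(O)cc(C)oc1=O`) has not yet been measured. Compared with compound 1, it has hexyl in place of hydrogen on a saturated chain carbon, nine bonds along the chain from a carbonyl carbon, which extends the chain that compound 1 already carries. For the measured compounds named here, one measured step bears on this change, and it runs the opposite way, shortening that chain: an at least 1.4-fold higher number from compound 1 to compound 3 (0.17 log units; that floor lies within the scatter). This is only a floor on the true size of the step, so it offers weak guidance.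

Going by that step from compound 1, a modest shift to a lower number in this assay is expected on lengthening the chain, possibly no larger than the scatter. The expected step is a 1.7-fold lower number from compound 1 to compound 4 (0.22 log units; within the scatter). Compound 4 is estimated at 80000 nM. The expected range for compound 4 runs from 25000 nM to 200000 nM.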

Compound 4, half-maximal inhibitory concentration: 165000 nM
Estimate against measurement, compound 4: 2.1-fold (0.31 log units) below, and the stated range covers the measured number.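

Hexyl in place of hydrogen on a saturated chain carbon, nine bonds along the chain from a carbonyl carbon, leaves this assay with a 1.2-fold higher number from compound 1 to compound 4 (0.09 log units; within the scatter). This position therefore takes the longer chain without a shift that can be told from the scatter, and the small drop in the number hinted at by the shortening step to compound 3 does not appear. This is also the first step along the chain with exact numbers at both ends, so its size can be read directly rather than as a floor.

Still open, on these data alone, is whether a carboxylic acid or an amine at the end of the chain would move the number beyond the scatter. Also open is how far the shorter chains differ from compound 1, as their values stop at a limit: the limit of > 200000 nM in this assay, at which 2 of the 4 values shown sit.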